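The source may report more compounds than this note shows. Statements on the series, on what has been measured and on what is new or still open speak of the compounds shown alone.

Measured compounds: compound 1 `O=C(O)c1ccccc1-c1ccc(CCc2ncc(CC3CC3)[nH]2)cc1` with 1000 nM in an in vitro functional assay on cells for agonist activity at Bombesin receptor subtype-3 (Homo sapiens), read by luminescence and calcium flux (on this read-out higher numbers stand for an effect only at larger amounts of compound and lower numbers for an effect already at smaller amounts), and compound 2 `CCC(C)(CC)Cc1cnc(CCc2ccc(-c3ccccc3C(=O)O)cc2)[nH]1` with 76 nM.

Among the measured compounds shown here, compound 2 holds the lower of the two numbers; the change a 13-fold lower number from compound 1 to compound 2 (1.12 log units; beyond the scatter) is the only measured step at this position. Compound 3 `Cc1ccc(Cc2cnc(CCc3ccc(-c4ccccc4C(=O)O)cc3)[nH]2)cc1` differs from compound 2 by 4-methylphenyl in place of 1-ethyl-1-methylpropyl on a saturated chain carbon bound to an aromatic carbon. For the measured compounds named here, no measured step involves an aromatic group at this place, so the move into compound 3 is not directly covered; the one step touching this position shows the site tolerates a change in group size. For compound 3 a moderate weakening is expected, a 3.3-fold higher number from compound 2 to compound 3 (0.52 log units; beyond the scatter), giving an estimate of 250 nM with a range from 60 nM to 1000 nM.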

Compound 3, half-maximal effective concentration: 2660 nM
Compound 3: middle estimate off by 11-fold (1.03 log units), on the low side; the measured number lies above the stated range.
By their numbers in this assay, from the lowest: compound 2; then compound 1; then compound 3.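

In this assay, the site proves far less forgiving than the earlier step suggested: an aromatic group here gives a 35-fold higher number from compound 2 to compound 3 (1.54 log units; beyond the scatter) and so loses all the gain seen with the branched chain. Even against the small cyclopropyl, 4-methylphenyl gives a 2.7-fold higher number from compound 1 to compound 3 (0.42 log units; beyond the scatter) as a modest step in the same direction. Nothing available explains this drop.

On these data alone, whether the loss belongs to the aromatic ring itself or to its methyl stays open. So does how an unsubstituted phenyl or a saturated cyclohexyl would compare at this place.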